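Replacing 2,4-dimethoxyphenyl with 4-fluorophenyl on a sulfonyl sulfur

This account rests on a few compounds, and the source may have more. Where it says the series, first, only, none or still open, it means among the compounds named here.

Compounds measured in a functional assay on HL-60 cells (Homo sapiens) for cytotoxicity, read by MTT assay; a higher number here means a weaker inhibitor, a lower number a stronger inhibitor:
Compound 1 `CC(C)C(NS(=O)(=O)c1ccc(F)cc1)C1=CC(=O)c2c(O)ccc(O)c2C1=O`: "not determined" (no result reported)
Compound 2 `Cc1ccccc1S(=O)(=O)NC(C)C1=CC(=O)c2c(O)ccc(O)c2C1=O`: 70 nM
Compound 3 `COc1ccc(S(=O)(=O)NC(C)C2=CC(=O)c3c(O)ccc(O)c3C2=O)c(OC)c1`: 500 nM

Compound 3 has the higher of the two numbers available in this assay, and compound 1 offers no number for comparison. Compound 4 `CC(NS(=O)(=O)c1ccc(F)cc1)C1=CC(=O)c2c(O)ccc(O)c2C1=O` carries 4-fluorophenyl in place of 2,4-dimethoxyphenyl on a sulfonyl sulfur. Within the data shown here, only one measured step bears on this change. It is a 7.1-fold higher number from compound 2 to compound 3 (0.85 log units; beyond the scatter), which came with 2,4-dimethoxyphenyl in place of 2-methylphenyl at the same place, and it lies beyond the scatter. Compound 1 shares the 4-fluorophenyl group, but without a number it gives no guide. Removing 2,4-dimethoxyphenyl may therefore recover part of that step, although the data do not show that 4-fluorophenyl matches 2-methylphenyl. The expected step is a 3.3-fold lower number from compound 3 to compound 4 (0.52 log units; beyond the scatter), a move towards a lower number of similar or smaller size. Compound 4 is estimated at 150 nM, with an expected range of 50 nM to 450 nM.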

Compound 4, half-maximal inhibitory concentration: 90 nM
For compound 4 the middle estimate is 1.7-fold (0.22 log units) above the measured one; the range from low to high includes it.
By their numbers in this assay, from the lowest: compounds 2 and 4 (each within the scatter of the next); then compound 3.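

In this assay, the step of a 5.6-fold lower number from compound 3 to compound 4 (0.74 log units; beyond the scatter) shows that a second group on the sulfonyl sulfur also gives a clearly lower number than 2,4-dimethoxyphenyl, so the high number of compound 3 is not a one-off contrast with 2-methylphenyl. Among these compounds, the step of a 1.3-fold higher number from compound 2 to compound 4 (0.11 log units; within the scatter) lies within the scatter, so 4-fluorophenyl and 2-methylphenyl are not separated here, and of the three measured compounds only the one with 2,4-dimethoxyphenyl stands apart. No measurement given here explains this difference.

The compounds shown leave open how plain phenyl, 4-methoxyphenyl or 2-methoxyphenyl would read at this place, and so which part of 2,4-dimethoxyphenyl goes with the higher number. Compound 1 gives "not determined" (no result reported) in this assay, so what its change away from compound 4 does to the number remains unread.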